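Neopentyl to 4-fluorophenyl on the ring amide side chain

The source may report more compounds than this note shows. Statements on the series, on what has been measured and on what is new or still open speak of the compounds shown alone.

Measured so far:
compound 1, `CS(=O)(=O)Nc1ccc2c(c1)S(=O)(=O)N=C(C1=C(O)[C@H]3CCC[C@H]3N(Cc3ccc(F)c(F)c3)C1=O)N2`, > 1 h
compound 2, `CC(C)(C)CCN1C(=O)C(C2=NS(=O)(=O)c3cc(NS(C)(=O)=O)ccc3N2)=C(O)C2CCCCC21`, 0.267 h

Going by the values given here, in an in vitro ADME assay on microsomes from liver (Homo sapiens) for metabolic stability (a higher number here means that the compound lasts longer, a lower number that the compound disappears faster), compound 2 gives 0.267 h, the only number in the set. Among the compounds with values here, compound 1 sits at the limit of > 1 h in this assay, at which 1 of the 2 values shown sits; this is a limit of this assay and not a number, so compound 2 is the only compound with a measured half-life to place.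

Compound 3, `CS(=O)(=O)Nc1ccc2c(c1)S(=O)(=O)N=C(C1=C(O)C3CCCCC3N(Cc3ccc(F)cc3)C1=O)N2`, is not yet measured. It differs from compound 2 by 4-fluorophenyl in place of neopentyl on a saturated chain carbon bound to an amide-type nitrogen in a ring. Within the data shown here, no measured step covers this change, so the expectation rests on the two values shown: one number and one limit. With compound 1 reaching the limit, a step upward in this assay is expected, of a size a 3.0-fold higher number from compound 2 to compound 3 (0.48 log units; beyond the scatter) that clears the usual scatter. Compound 3 is therefore estimated at 0.8 h, with a range from 0.3 h to 2 h, and a real chance that the assay again reports only a limit.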

Compound 3, half-life: > 1 h
Compound 3: only a limit was reported; the forecaster's own chance of this, stated with the estimate: 40%; at least 1.2-fold (0.09 log units) between middle value and limit.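

In this assay, going by these compounds alone, 4-fluorophenyl in place of neopentyl on a saturated chain carbon bound to an amide-type nitrogen in a ring gives an at least 3.7-fold higher number from compound 2 to compound 3 (0.57 log units; beyond the scatter), the first measured step at this position. Compound 3 gives > 1 h, which is a limit of the assay and not a number. The step therefore fixes a direction and a lower bound on its size, while the full size remains unresolved: the limit of > 1 h in this assay, at which 2 of the 3 values shown sit.

From the compounds shown here alone, how far the half-life of compound 3 lies past its limit remains open, as does whether the gain follows the aromatic ring or the fluorine. Whether a plain benzyl group, or a chain ending in an amine or a carboxylic acid, would hold the same half-life at this position is also unresolved.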